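The source may report more compounds than this note shows. Statements on the series, on what has been measured and on what is new or still open speak of the compounds shown alone.

Measured in a functional assay on Gurav cells (Homo sapiens) for inhibition, read by sulforhodamine B assay; a lower number here means a stronger inhibitor of growth, a higher number a weaker inhibitor of growth:
- Compound 1 `c1ccc(-c2ccc(-c3ccc(-c4nc5ccccc5[nH]4)cc3)cc2)cc1`: 100000 nM
- Compound 2 `FC(F)(F)c1ccc(-c2ccc(-c3ccc(-c4nc5ccccc5[nH]4)cc3)cc2)cc1`: 39100 nM
- Compound 3 `Oc1cccc2[nH]c(-c3ccc(-c4ccc(-c5ccccc5)cc4)cc3)nc12`: 1110 nM

Compound 3 has the lowest number of the three in this assay. Compound 4 `Oc1ccc(-c2ccc(-c3ccc(-c4nc5c(O)cccc5[nH]4)cc3)cc2)cc1` differs from it by hydroxy in place of hydrogen on an aromatic carbon, which turns phenyl to 4-hydroxyphenyl. Going by the values given here, two measured steps bear on this. Trifluoromethyl in place of hydrogen gave a 2.6-fold lower number from compound 1 to compound 2 (0.41 log units; beyond the scatter), a modest gain at the phenyl end. Hydroxy in place of hydrogen gave a 90-fold lower number from compound 1 to compound 3 (1.95 log units; beyond the scatter), a large gain, but at a different place. A modest move to a lower number is therefore expected, the estimated step being a 2.0-fold lower number from compound 3 to compound 4 (0.30 log units; within the scatter). For compound 4 the estimated value is 550 nM, with an expected range of 120 nM to 2500 nM.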

Compound 4, concentration for 50% growth inhibition: 190 nM
Compound 4: middle estimate off by 2.9-fold (0.46 log units), on the high side, within the range that was stated.
By their numbers in this assay, from the lowest: compound 4; then compound 3; then compound 2; then compound 1.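

In this assay, the change from phenyl to 4-hydroxyphenyl gave a 5.8-fold lower number from compound 3 to compound 4 (0.77 log units; beyond the scatter) beyond the scatter, so this end still responds to hydroxy when the core already carries one. Hydroxy is thus the second group shown here to lower the number, after trifluoromethyl in a 2.6-fold lower number from compound 1 to compound 2 (0.41 log units; beyond the scatter) on a core without hydroxy. No measurement shown explains why hydroxy has this effect. As far as these compounds go, whether an amine, a methoxy group or a carboxylic acid in the same place would lower the number remains open. So does whether this gain requires the hydroxy on the core.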